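A few compounds are considered here, and "the series" means these few. Any claim that something is new, unique, unknown or untested is made for them only; others in the source may bear on it.

Measured in an assay on HeLa cells for inhibition of Indoleamine 2,3-dioxygenase 1 (Homo sapiens), read by spectrophotometry, with a stated time of 24 h; on this read-out higher numbers stand for an effect only at larger amounts of compound and lower numbers for an effect already at smaller amounts:

- compound 1 `Cc1cccc(NNS(=O)(=O)c2ccc(S(C)(=O)=O)cc2)c1`: 7850 nM
- compound 2 `CC(=O)Nc1ccc(S(=O)(=O)NNc2cccc(Br)c2)cc1`: 7560 nM
- compound 3 `O=S(=O)(NNc1ccc(Br)cc1)c1ccc(Br)cc1`: 374 nM

Compound 3 stands at the lowest number of the three. The nearest is compound 2, whose number is higher by a gap beyond the scatter; the furthest is compound 1, also beyond the scatter. The two weaker compounds each carry a methylsulfonyl or an acetamido group where compound 3 carries a bromo, and both sit far above compound 3 in this assay.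

Compound 4 `O=C(O)CCc1ccc(S(=O)(=O)NNc2ccc(Br)cc2)cc1` has not yet been measured. It differs from compound 3 by 2-carboxyethyl in place of bromo on an aromatic carbon. No step between measured compounds covers this exchange, so the expectation rests on the three numbers shown. Since the two compounds without a bromo at that ring, compound 1 with 7850 nM and compound 2 with 7560 nM, give much higher numbers than compound 3, a rise beyond the scatter is expected from compound 3 to compound 4, about a 13-fold higher number from compound 3 to compound 4 (1.13 log units; beyond the scatter). Compound 4 is estimated at 5000 nM, within a range from 1000 nM to 25000 nM.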

Compound 4, half-maximal effective concentration: 183 nM
Compound 4: the middle estimate sits 27-fold (1.44 log units) above what was measured; measured number below the stated range.
By their numbers in this assay, from the lowest: compound 4; then compound 3; then compounds 2 and 1 (each within the scatter of the next).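

In this assay the exchange of bromo for 2-carboxyethyl on an aromatic carbon, para to a large group, gives a 2.0-fold lower number from compound 3 to compound 4 (0.31 log units; beyond the scatter) and so shows that this position tolerates a larger group carrying a hydrogen-bond donor and acceptor, with no bromo needed there. Within the data shown here, compounds 1 and 2 each differ from compound 3 in more than one place, so this is the first pair in which the position can be read on its own. Nothing available bears on why the number falls with this exchange.

Open, going by these compounds, is whether the carboxylic acid or the chain carries the step: a methyl ester, a primary amide or a plain propyl chain at this position would separate the two. Also open, on these data alone, is whether the step holds when the other side of the core changes, as this pair keeps that side fixed.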